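A few compounds are considered here, and "the series" means these few. Any claim that something is new, unique, unknown or untested is made for them only; others in the source may bear on it.

Measured compounds in a functional assay on MCF7 cells (Homo sapiens) for cytotoxicity, read by MTT assay, with a stated time of 24 h; on this read-out lower numbers stand for stronger inhibition and higher numbers for weaker inhibition:
compound 1, `Cc1cc(O)c(C(=O)/C=C/c2ccccc2)c(-c2ccc(Br)cc2)c1C(=O)/C=C/c1ccccc1`, gives 10000 nM
compound 2, `Cc1cc(O)c(C(=O)/C=C/c2ccccc2)c(-c2ccc(OCc3ccccc3)cc2)c1C(=O)/C=C/c1ccccc1`, gives "not active" (no number reported)

For the measured compounds named here, compound 2 stands without a number: in this assay compound 2 is reported as "not active" (no number reported), so no distance to compound 1 can be set, and no step between the two is given. Compound 1 carries a bromo where compound 2 carries a benzyloxy, and in this assay compound 1 gives 10000 nM.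

Compound 3, `Cc1cc(O)c(C(=O)/C=C/c2ccccc2)c(-c2ccc(Cl)cc2)c1C(=O)/C=C/c1ccccc1`, is the next target. The change from compound 2 is chloro in place of benzyloxy on an aromatic carbon, in words chloro in place of benzyloxy on an aromatic carbon. Going by the values given here, the outcome of compound 2 gives no anchor for the size of this step, only that compound 2 shows nothing measurable while compound 1, with bromo at the same place, does. The expectation for compound 3 is therefore a number near that of compound 1 in this assay, with a real chance that only a limit is reported.

For compound 3 the estimate in this assay is 10000 nM, with a range from 4000 nM to 30000 nM.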

Compound 3, half-maximal inhibitory concentration: 15000 nM
The estimate for compound 3 lay 1.5-fold (0.18 log units) below the measured number; low and high end bracket the measured number.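

Chloro in place of bromo on an aromatic carbon gives a 1.5-fold higher number from compound 1 to compound 3 (0.18 log units; within the scatter) in this assay so the two groups cannot be told apart at this place. With compound 3 at 15000 nM this position now has two groups with a number, while benzyloxy in compound 2 has none, and the step from compound 2 to compound 3 cannot be read. Nothing available explains the match between chloro and bromo or the missing number for benzyloxy at this place.

From the compounds shown here alone, whether fluoro, methoxy, an amine or a carboxylic acid at this place would still give a number in this assay stays open. Also open, going by these compounds, is whether any group here can give a number clearly lower than those of the chloro and bromo compounds, since these two values alone show no trend.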